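Pyridin-2-yl in place of a chlorinated phenyl on the hydrazone

The source may report more compounds than this note shows. Statements on the series, on what has been measured and on what is new or still open speak of the compounds shown alone.

Compound 1, `Cc1ccc(NN=C2CCC(C)n3c2ncc(C(=O)O)c3=O)cc1C`, in a functional assay on the whole organism with Rattus norvegicus as the target (a lower number here means that less compound is needed, a higher number that more compound is needed for the effect), gives > 100 umol/kg, which is a limit of the assay. Compound 2, `CC1CCC(=NNc2ccc(Cl)cc2Cl)c2ncc(C(=O)O)c(=O)n21`, gives > 100 umol/kg, likewise a limit. Compound 3, `Cc1cccc(Cl)c1NN=C1CCC(C)n2c1ncc(C(=O)O)c2=O`, gives > 100 umol/kg, again a limit.

Compound 3 therefore stands exactly where the other two stand: the limit of > 100 umol/kg in this assay, at which 3 of the 3 values shown sit. The steps a step that the two limits leave unreadable from compound 1 to compound 2, a step that the two limits leave unreadable from compound 1 to compound 3 and a step that the two limits leave unreadable from compound 2 to compound 3 are all unreadable, so none of them tells how large a change of the aryl group on this nitrogen can be. Compound 4, `CC1CCC(=NNc2ccccn2)c2ncc(C(=O)O)c(=O)n21`, differs from compound 3 in one place: pyridin-2-yl in place of 2-chloro-6-methylphenyl on an amine nitrogen. For the measured compounds named here, no measured step bears readably on this change, so the expected step that the limit leaves unreadable from compound 3 to compound 4 rests on the shared position at the limit alone. Compound 4 is estimated at 150 umol/kg, between 40 umol/kg and 600 umol/kg, most likely reported as a limit.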

Compound 4, dose for 50% inhibition: > 100 umol/kg
Compound 4: no number, only a limit; the forecaster's own chance of this, stated with the estimate: 75%; the middle value is on the limit's open side.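

In this assay compound 4 gives > 100 umol/kg, which is a limit. Its steps from compound 1, compound 2 and compound 3 cannot be read: the limit of > 100 umol/kg in this assay, at which 4 of the 4 values shown sit.

The compounds shown leave open whether any of these groups on the amine nitrogen changes the dose needed.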